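Butyl for isopropyl on a new core: a projected dose

This account rests on a few compounds, and the source may have more. Where it says the series, first, only, none or still open, it means among the compounds named here.

Measured so far, with the dose for half-maximal inhibition:
compound 1 `CC(C)Oc1ccccc1-c1ncc(C(=O)O)c(=O)[nH]1` 0.8 mg/kg
compound 2 `CCCCOc1ccccc1-c1ncc(C(=O)O)c(=O)[nH]1` 0.5 mg/kg
compound 3 `CCOC(=O)c1cnc(-c2ccccc2OC(C)C)[nH]c1=O` 2 mg/kg

All three were tested in a functional assay on the whole organism (strain Sprague-Dawley) for inhibition, with Rattus norvegicus as the target, with a stated time of 10 min; a lower number here means that less compound is needed, a higher number that more compound is needed for the effect. Compound 1 and compound 2 share a core and differ only by butyl in place of isopropyl on an oxygen on an aromatic ring; that change gave a 1.6-fold lower number from compound 1 to compound 2 (0.20 log units; within the scatter). Compound 3 carries a different core: it differs from compound 1 by ethyl in place of hydrogen on an oxygen next to a carbonyl group, which gave a 2.5-fold higher number from compound 1 to compound 3 (0.40 log units; beyond the scatter), the highest dose of the three.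

Compound 4 `CCCCOc1ccccc1-c1ncc(C(=O)OCC)c(=O)[nH]1` has not yet been tested. It differs from compound 3 by butyl in place of isopropyl on an oxygen on an aromatic ring. The place where the change sits reads the same in both pairs, so this is the same change as that from compound 1 to compound 2, now made on the core of compound 3.

Because a 1.6-fold lower number from compound 1 to compound 2 (0.20 log units; within the scatter) lay within the scatter, the expected step here is also small: a 1.5-fold lower number from compound 3 to compound 4 (0.19 log units; within the scatter) is estimated for compound 4. On that basis compound 4 is expected to give about 1.3 mg/kg in this assay, most likely between 0.6 mg/kg and 3 mg/kg.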

Compound 4, dose for 50% inhibition: 0.5 mg/kg
For compound 4 the middle estimate is 2.6-fold (0.41 log units) above the measured one; the whole stated range lies above it.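

On the core of compound 3, butyl in place of isopropyl on an oxygen on an aromatic ring gives a 4.0-fold lower number from compound 3 to compound 4 (0.60 log units; beyond the scatter) in this assay, and this step cannot be told apart from the one on the core of compound 1: the same change on two cores in this assay, a 1.6-fold lower number (0.20 log units; within the scatter) from compound 1 to compound 2 and a 4.0-fold lower number (0.60 log units; beyond the scatter) from compound 3 to compound 4, 2.5-fold (0.40 log units) apart, within the scatter of two such steps. Ethyl in place of hydrogen on an oxygen next to a carbonyl group gives no change at the digits printed from compound 2 to compound 4 (within the scatter), and this step likewise cannot be told apart from its earlier counterpart: the same change on two cores in this assay, a 2.5-fold higher number (0.40 log units; beyond the scatter) from compound 1 to compound 3 and no change at the digits printed (within the scatter) from compound 2 to compound 4, 2.5-fold (0.40 log units) apart, within the scatter of two such steps. These pairs fit changes that carry from one core to the other, but they do not fix the size of the butyl step: one of its two readings lies within the scatter and the other beyond it.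

The compounds shown leave open whether a longer chain, such as hexyl, on the same oxygen would follow the butyl result. They also leave open how an amide in place of the carboxylic acid or ethyl ester would read in this assay.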